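A Phenyl Amide in Place of Propargyl

The source may report more compounds than this note shows. Statements on the series, on what has been measured and on what is new or still open speak of the compounds shown alone.

In a functional assay on B16 cells (Mus musculus) for cytotoxicity, read by MTT assay, with a stated time of 48 h (a higher number here means a weaker inhibitor, a lower number a stronger inhibitor), compound 1 `C#CCNC(=O)c1cn(Cc2ccccc2)nn1` gives 65000 nM. Compound 2 `C#CCNC(=O)c1cn(CCOC(C)=O)nn1` gives no number, only a limit of > 100000 nM. Compound 3 `CC(=O)OCCn1cc(CNC(=O)c2cn(CC(=O)OCc3ccccc3)nn2)nn1` likewise gives only a limit, > 100000 nM. Compound 2 therefore stands at the limit of > 100000 nM in this assay, at which 2 of the 3 values shown sit.

Compound 4 `CC(=O)OCCn1cc(C(=O)Nc2ccccc2)nn1` differs from compound 2 by having phenyl in place of propargyl on an amide-type nitrogen.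

One measured step lies close to this comparison: an at least 1.5-fold higher number from compound 1 to compound 2 (0.18 log units; that floor lies within the scatter). That step concerns acetoxymethyl in place of phenyl on a saturated chain carbon bound to an aromatic nitrogen, so it does not touch the amide-type nitrogen. For the measured compounds named here, no measured step covers the change in compound 4, and its true size remains open. No step beyond the scatter is therefore expected in this assay, although a small move towards a lower number is possible. The expected change is an at least 1.1-fold lower number from compound 2 to compound 4 (0.04 log units; that floor lies within the scatter). For compound 4 the estimate is 90000 nM, with an expected range from 35000 nM to 170000 nM.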

Compound 4, half-maximal inhibitory concentration: > 100000 nM
Compound 4 was reported as a limit; the forecaster's own chance of this, stated with the estimate: 55%; middle value at least 1.1-fold (0.04 log units) from the limit.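

In this assay compound 4 gives only a limit, > 100000 nM. Compound 2 also gives only a limit, so no step can be read between compound 2 and compound 4. Compound 4 stands with compound 2: the limit of > 100000 nM in this assay, at which 3 of the 4 values shown sit.

The compounds shown leave open whether phenyl or propargyl on the amide-type nitrogen gives the lower number.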